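Cytotoxicity of ether variants in the series

A few compounds are considered here, and "the series" means these few. Any claim that something is new, unique, unknown or untested is made for them only; others in the source may bear on it.

Compound 1 `CCC1(Cc2ccccc2)OS(=O)(=O)C=C1OC` and compound 2 `CCC1(Cc2ccccc2)OS(=O)(=O)C=C1OCC1CCCCC1` share the same core and differ only in the ether side chain, cyclohexyl in place of hydrogen on a saturated chain carbon bound to an oxygen on an unsaturated carbon. In an ADME assay on HEL cells (Homo sapiens) for cytotoxicity, with a stated time of 3 days (on this read-out higher numbers stand for lower toxicity in this test and lower numbers for higher toxicity in this test), compound 1 gives only a limit, > 200000 nM. In this assay compound 2 likewise gives only a limit, > 200000 nM. The step that the two limits leave unreadable from compound 1 to compound 2 therefore cannot be read, and this is all that the limit of > 200000 nM in this assay, at which 2 of the 2 values shown sit, allows: compound 2 stands at the limit, with no number to rank it against.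

Compound 3 `CCC1(Cc2ccccc2)OS(=O)(=O)C=C1OCc1cccc(Cl)c1` is the next variant, (3-chlorophenyl in place of cyclohexyl on a saturated chain carbon bound to an oxygen on an unsaturated carbon). For the measured compounds named here, only the step from compound 1 to compound 2 bears on this change, and it is unreadable, so no direction in this assay can be taken from it; the expectation is simply that compound 3 stays at the limit like compound 2. The estimated step that the limit leaves unreadable from compound 2 to compound 3 is expected to be none beyond the scatter. Compound 3 is estimated at 250000 nM, within 100000 nM to 600000 nM, most likely again reported as a limit.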

Compound 3, half-maximal cytotoxic concentration: 50000 nM
For compound 3 the middle estimate is 5.0-fold (0.70 log units) above the measured one; measured number outside the range, below it.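

At the place on a saturated chain carbon bound to an oxygen on an unsaturated carbon, the ether side chain can shift the read-out in this assay: 3-chlorophenyl in place of cyclohexyl gives an at least 4.0-fold lower number from compound 2 to compound 3 (0.60 log units; beyond the scatter). Against the smallest ether, 3-chlorophenyl in place of hydrogen gives an at least 4.0-fold lower number from compound 1 to compound 3 (0.60 log units; beyond the scatter), so both steps point to higher toxicity in this test for compound 3. Compound 3 is the only compound in the set with a number rather than a limit, and both steps are minimum sizes, because the other two compounds give only limits: the limit of > 200000 nM in this assay, at which 2 of the 3 values shown sit.

The change swaps a six-membered non-aromatic ring for a six-membered aromatic ring and adds a chlorine at once, so the compounds shown leave open which of the two goes with the lower number, a question that a plain benzyl ether on the shared core would separate. On these data alone, how a longer chain or an amine in the ether side chain would read in this assay also remains open.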